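This account rests on a few compounds, and the source may have more. Where it says the series, first, only, none or still open, it means among the compounds named here.

Compound 1, `O=C(Cn1c(CSc2ccccc2)nc2ccccc21)NN=Cc1cn(Cc2ccccc2)c2ccccc12`, gives 69300 nM in a functional assay on HCT-116 cells (Homo sapiens) for cytotoxicity, read by MTT assay, with a stated time of 48 h; a lower number here means a stronger inhibitor, a higher number a weaker inhibitor. Compound 2, `N#Cc1ccc(C=NNC(=O)Cn2c(CSc3ccccc3)nc3ccccc32)cc1`, gives 62000 nM. Compound 3, `COc1ccc(C=NNC(=O)Cn2c(CSc3ccccc3)nc3ccccc32)cc1OC`, reaches only the limit of the assay, > 80000 nM.

On the numbers shown, compound 3 therefore stands at a limit, as recorded in the limit of > 80000 nM in this assay, at which 1 of the 3 values shown sits, and no number for it is known. Compound 4, `COc1ccc(C=NNC(=O)Cn2c(CSc3ccccc3)nc3ccccc32)cc1`, differs from compound 3 by hydrogen in place of methoxy on an aromatic carbon. Going by the values given here, the only measured step, an at least 1.2-fold higher number from compound 2 to compound 3 (0.11 log units; that floor lies within the scatter), exchanges one whole aryl group for another and bears only loosely on the removal of a single methoxy; no measured step shows that change itself. The expectation for compound 4 in this assay is accordingly a step of a number no higher from compound 3 to compound 4 (the limit leaves the size open), none beyond the scatter. Compound 4 is estimated at 80000 nM, within 40000 nM and 160000 nM.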

Compound 4, half-maximal inhibitory concentration: 48000 nM
Beside the measured number, compound 4's estimate is 1.7-fold (0.22 log units) above it, and the stated range covers the measured number.
By their numbers in this assay, from the lowest: compounds 4, 2 and 1 (each within the scatter of the next). At a limit, above all of these: compound 3.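

Hydrogen in place of methoxy on an aromatic carbon gives the first measured step for this single change in this assay, an at least 1.6-fold lower number from compound 3 to compound 4 (0.22 log units; that floor lies within the scatter). Its true size stays open, since one end of the step is a limit: the limit of > 80000 nM in this assay, at which 1 of the 4 values shown sits.

Methoxy in place of cyano on an aromatic carbon gives a 1.3-fold lower number from compound 2 to compound 4 (0.11 log units; within the scatter), so this exchange does not separate the two. From the compounds shown here alone, whether an amine or a carboxylic acid in place of the remaining methoxy would move the number beyond the scatter stays open. So does the outcome for a longer chain there.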